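This account rests on a few compounds, and the source may have more. Where it says the series, first, only, none or still open, it means among the compounds named here.

Compound 3 `CCCn1c(=O)c(-c2cccc([N+](=O)[O-])c2)nc2ccccc21`: 177 nM
Compound 1 `O=c1c(-c2ccc(F)c([N+](=O)[O-])c2)nc2ccccc2n1Cc1ccccc1`: 690 nM
Compound 2 `O=c1c(-c2cccc([N+](=O)[O-])c2)nc2ccc(Cl)cc2n1Cc1ccccc1`: 760 nM

In an assay on cells for activation of Cystic fibrosis transmembrane conductance regulator (Homo sapiens), read by fluorescence, with a stated time of 10 min (on this read-out lower numbers stand for an effect already at smaller amounts and higher numbers for an effect only at larger amounts of compound), compound 3 gives the lowest of the three numbers, and its gaps to compound 1 and to compound 2 both lie beyond the usual scatter. Compound 4 `O=c1c(-c2cccc([N+](=O)[O-])c2)nc2ccccc2n1Cc1ccco1` differs from compound 3 by furan-2-yl in place of ethyl on a saturated chain carbon bound to an aromatic nitrogen. For the measured compounds named here, no measured pair isolates this change: compounds 1 and 2 carry a different group on that nitrogen but also differ from compound 3 elsewhere, so their higher numbers cannot be credited to the chain alone. The step from compound 3 to compound 4 is expected to be small and towards higher numbers, a 1.7-fold higher number from compound 3 to compound 4 (0.23 log units; within the scatter), probably within the scatter. Compound 4 is accordingly estimated at 300 nM, with a range from 120 nM to 800 nM.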

Compound 4, half-maximal effective concentration: 20 nM
Beside the measured number, compound 4's estimate is 15-fold (1.18 log units) above it, and the stated range ends above it.
By their numbers in this assay, from the lowest: compound 4; then compound 3; then compounds 1 and 2 (each within the scatter of the next).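

In this assay, for the compounds shown here, furan-2-yl in place of ethyl on a saturated chain carbon bound to an aromatic nitrogen gives an 8.9-fold lower number from compound 3 to compound 4 (0.95 log units; beyond the scatter) and is the first change seen alone at this position. The position therefore responds to its group, with propyl to (furan-2-yl)methyl moving the number beyond the scatter. Nothing measured here explains the step.

Going by these compounds, whether a thiophen-2-ylmethyl group, a longer chain or an amine there would give a similar number stays open. So does whether this step carries over to the cores of compound 1 and compound 2.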